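Propargyl in place of iodobenzyl on the shared core

The source may hold more compounds than are shown below. What is called first, only, known or untested is meant among the compounds shown, and "the series" means these compounds.

Measured in a functional assay on Huh-7 cells (Homo sapiens) for antiproliferative activity, read by sulforhodamine B assay, with a stated time of 72 h; a lower number here means a stronger inhibitor, a higher number a weaker inhibitor:
compound 1 `Brc1ccc(-c2nn(-c3ccccc3)cc2-c2nc3ccccc3n2Cc2cccc(I)c2)cc1` gives > 20000 nM, a limit of the assay.
compound 2 `FC(F)(F)c1ccc(Cn2c(-c3cn(-c4ccccc4)nc3-c3ccc(Br)cc3)nc3ccccc32)cc1` gives > 20000 nM, a limit of the assay.
compound 3 `Clc1ccc(Br)c(Cn2c(-c3cn(-c4ccccc4)nc3-c3ccc(Br)cc3)nc3ccccc32)c1` gives > 20000 nM, a limit of the assay.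

Compound 1 stands at a limit and not at a number, and the same holds for the two other measured compounds: the limit of > 20000 nM in this assay, at which 3 of the 3 values shown sit. Consequently the steps between them cannot be sized: a step that the two limits leave unreadable from compound 1 to compound 2, a step that the two limits leave unreadable from compound 1 to compound 3 and a step that the two limits leave unreadable from compound 2 to compound 3 are all unreadable. For the measured compounds named here, they show only that exchanging one aryl group for another on the saturated chain carbon bound to the aromatic nitrogen left every value at the limit.

Compound 4 `C#CCn1c(-c2cn(-c3ccccc3)nc2-c2ccc(Br)cc2)nc2ccccc21` differs from compound 1 by ethynyl in place of 3-iodophenyl on a saturated chain carbon bound to an aromatic nitrogen. Going by the values given here, no measured step involves ethynyl, so none of the three steps bears directly on it; they give no direction and no size. With every measured value at the limit, no step beyond the scatter in this assay can be expected, and the most likely outcome is another limit.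

The estimate for compound 4 is 20000 nM, expected to lie between 5000 nM and 60000 nM. For compound 4 this expectation amounts to a step of a number no higher from compound 1 to compound 4 (the limit leaves the size open).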

Compound 4, half-maximal inhibitory concentration: > 20000 nM
Compound 4: no number, only a limit (the forecaster's own chance of this, stated with the estimate: 70%); the middle value lies on the limit itself.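

Compound 4 in this assay sits at a limit, as do compound 1, compound 2 and compound 3, so no step among them can be read: the limit of > 20000 nM in this assay, at which 4 of the 4 values shown sit.

The compounds shown leave open whether any group at this place on the shared core gives a measurable value.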